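The source may report more compounds than this note shows. Statements on the series, on what has been measured and on what is new or still open speak of the compounds shown alone.

Going by the values given here, in a functional assay on PANC-1 cells (Homo sapiens), read by microscopy, crystal violet staining and transwell migration, with a stated time of 18 h, in the presence of a further agent that is not named here (on this read-out lower numbers stand for stronger inhibition and higher numbers for weaker inhibition), compound 3 `CCc1nc(-c2ccc(OC(F)(F)F)cc2)n(-c2cccc(C(=O)NCCCCc3ccccc3)c2)n1` gives 640 nM, the lowest number measured so far. Compound 2 `COc1ccc(-c2nc(C)nn2-c2cccc(C(=O)NCCOCc3ccccc3)c2)cc1` gives 9340 nM. Compound 1 `COc1ccc(-c2nc(C)nn2-c2cccc(C(=O)NCCCc3ccc(Br)cc3)c2)cc1` gives > 20000 nM, which is a limit of the assay and not a number.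

Compound 4 `CCc1nc(-c2cnc(OC)cn2)n(-c2cccc(C(=O)NCCCCc3ccccc3)c2)n1` carries 5-methoxypyrazin-2-yl in place of 4-(trifluoromethoxy)phenyl on an aromatic carbon. Among the compounds with values here, the only measured step, an at least 2.1-fold lower number from compound 1 to compound 2 (0.33 log units; beyond the scatter), lies on a saturated chain carbon, two bonds along the chain from an amide-type nitrogen. Within the data shown here, it shows that one change can move the number in this assay, but it does not touch the aromatic carbon changed here, so no measured step gives the size of this one directly.

Since compound 3 holds the best number at 640 nM, a higher number is the more likely outcome, with wide uncertainty. The expected change is a 5.5-fold higher number from compound 3 to compound 4 (0.74 log units; beyond the scatter). The estimate for compound 4 is 3500 nM, with an expected range from 800 nM to 15000 nM.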

Compound 4, half-maximal inhibitory concentration: 310 nM
The estimate for compound 4 lay 11-fold (1.05 log units) above the measured number; measured number outside the range, below it.
By their numbers in this assay, from the lowest: compound 4; then compound 3; then compound 2. At a limit, above all of these: compound 1.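

Going by these compounds alone, at this position, on the aromatic carbon between two ring nitrogen atoms, the first measured change in this assay gives a 2.1-fold lower number from compound 3 to compound 4 (0.31 log units; beyond the scatter). The earlier compounds shown here left this place untested, and the step shows that 4-(trifluoromethoxy)phenyl is not needed to reach the lowest number so far: 5-methoxypyrazin-2-yl, with fewer heavy atoms and a ring holding 2 hetero atoms, takes its place without any loss. Nothing measured here accounts for the size or direction of this step.

Still open, as far as these compounds go, is which part of the new group matters: a pyridin-2-yl group or an unsubstituted phenyl at this place would separate the effect of the ring nitrogens from that of the methoxy. Also open, from the compounds shown here alone, is whether the same exchange gives a similar step with a methyl group in place of the ethyl group on the shared core.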